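Two Ethyl Groups in Place of One Methyl

The source may hold more compounds than are shown below. What is called first, only, known or untested is meant among the compounds shown, and "the series" means these compounds.

Of the compounds shown here, three sharing one core have been tested in a functional assay on MCF7 cells (Homo sapiens) for antiproliferative activity, read by MTT assay, with a stated time of 48 h; on this read-out lower numbers stand for stronger inhibition and higher numbers for weaker inhibition. Compound 1, `CCOc1ccc(-n2nncc2CN2C(=O)C3(C(C#N)=C(N)Oc4c3c3nc5ccccc5nc3c3ccccc43)c3ccccc32)cc1`, reaches only the limit > 50000 nM there. Compound 2, `N#CC1=C(N)Oc2c(c3nc4ccccc4nc3c3ccccc23)C12C(=O)N(Cc1cnnn1-c1ccc([N+](=O)[O-])cc1)c1ccccc12`, likewise gives only the limit > 50000 nM. The step that the two limits leave unreadable from compound 1 to compound 2 therefore cannot be read, since both ends sit at the same limit. Compound 3, `Cc1ccccc1-n1nncc1CN1C(=O)C2(C(C#N)=C(N)Oc3c(N)cc4nc5ccccc5nc4c32)c2ccccc21`, also stops at the limit > 50000 nM. For the measured compounds named here, all three values shown sit at the limit of > 50000 nM in this assay, at which 3 of the 3 values shown sit, so no measured step has a readable size and nothing ranks the three compounds against one another.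

Compound 4, `CCc1cccc(CC)c1-n1nncc1CN1C(=O)C2(C(C#N)=C(N)Oc3c(N)cc4nc5ccccc5nc4c32)c2ccccc21`, has not yet been measured. It differs from compound 3 in one place: 2,6-diethylphenyl in place of 2-methylphenyl on an aromatic nitrogen. Going by the values given here, no measured step touches this position; the only step on record, from compound 1 to compound 2, changes another group and is itself unreadable. The evidence thus offers neither direction nor size for the move to compound 4, and the expectation rests solely on where compound 3 stands. Compound 4 is therefore expected to remain at or near the limit, with an estimated step of a number no higher from compound 3 to compound 4 (the limit leaves the size open). The estimated value for compound 4 is 50000 nM, within a range from 15000 nM to 50000 nM, with a substantial chance that only a limit is reported again.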

Compound 4, half-maximal inhibitory concentration: > 50000 nM
Compound 4 ended at the assay's limit (the forecaster's own chance of this, stated with the estimate: 85%); the middle value lies on the limit itself.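

The step from compound 3 to compound 4 cannot be read, since both compounds stop at the same limit in this assay: the limit of > 50000 nM in this assay, at which 4 of the 4 values shown sit.

The compounds shown leave open how 2,6-diethylphenyl and 2-methylphenyl rank against each other, and whether any compound of this series gives a readable value in this assay.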